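The source may report more compounds than this note shows. Statements on the series, on what has been measured and on what is new or still open speak of the compounds shown alone.

Measured compounds:
compound 1, `N#Cc1cccc([C@]23CCC(N(CCN4CC[C@@H](O)C4)C(=O)Nc4ccccc4)CC2C3)c1`: 132 nM
compound 2, `CC(C)N(CCN(C(=O)Nc1ccc(F)c(Cl)c1)C1CC[C@]2(c3cccc(C#N)c3)CC2C1)C(C)C`: 4.98 nM

Both were run in a functional assay for antagonist activity at melanin-concentrating hormone receptor 1 (Homo sapiens); a higher number here means a weaker inhibitor, a lower number a stronger inhibitor. Compound 1 gives 132 nM; compound 2 gives 4.98 nM. Of the two numbers, compound 2 stands at the lower one, and the gap between the two measured compounds is beyond the scatter. For the measured compounds named here, no single-change step between measured compounds is available in this set, so the two values only show that compound 2 is the stronger of the pair.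

Compound 3, `CC(C)N(CCN(C(=O)Nc1cccc(Br)c1)C1CC[C@]2(c3cccc(C#N)c3)CC2C1)C(C)C`, is not yet measured. It differs from compound 2 in one place: 3-bromophenyl in place of 3-chloro-4-fluorophenyl on an amide-type nitrogen. Both groups are halogenated phenyl rings on the same amide-type nitrogen, and nothing measured here bears on this swap. The step from compound 2 to compound 3 in this assay is expected to be small, a 1.6-fold higher number from compound 2 to compound 3 (0.21 log units; within the scatter), within or close to the scatter, with a slight lean toward a higher number. Compound 3 is therefore estimated at 8 nM, in the range 2.5 nM to 25 nM.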

Compound 3, inhibition constant: 5.7 nM
For compound 3 the middle estimate is 1.4-fold (0.15 log units) above the measured one; low and high end bracket the measured number.
By their numbers in this assay, from the lowest: compounds 2 and 3 (each within the scatter of the next); then compound 1.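

For the compounds shown here, the step of a 1.1-fold higher number from compound 2 to compound 3 (0.06 log units; within the scatter) in this assay is the first single-change reading, and it concerns the aryl group on the amide-type nitrogen. On the shared core of compound 2 and compound 3, 3-bromophenyl and 3-chloro-4-fluorophenyl cannot be told apart in this assay, so this position holds either halogen pattern at the same level, even with one heavy atom fewer in the 3-bromophenyl group. Nothing available explains why the two groups read alike. As far as these compounds go, what stays open is whether a ring without halogen, such as 3-methoxyphenyl or a pyridine ring, would read the same at this nitrogen. From the compounds shown here alone, a carboxylic acid or a primary amine on the phenyl ring is equally open, so the tolerance seen here extends only to these two halogenated phenyl groups.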